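The source may report more compounds than this note shows. Statements on the series, on what has been measured and on what is new or still open speak of the compounds shown alone.

Of the compounds shown here, two have been measured in an in vitro assay on BL21-DE3 cells for displacement of a labelled ligand from thyroid hormone receptor beta (Homo sapiens), read by fluorescence polarization; on this read-out lower numbers stand for stronger inhibition and higher numbers for weaker inhibition. Compound 1, `CCCCCCc1ccc(C(=O)/C=C\C(=O)O)cc1`, carries an acid-bearing chain on its carbonyl and gives 17700 nM. Compound 2, `C/C=C/C(=O)c1ccc(CCCCCCC)cc1`, carries a prop-1-en-1-yl group on the same carbonyl and gives 7600 nM. Of the two numbers, compound 2 has the lower one, and the gap to compound 1 lies beyond the usual scatter of repeated measurements, so compound 2 is the stronger binder of the pair so far.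

Compound 3, `C=C(C)C(=O)c1ccc(CCCCCCC)cc1`, has the same atoms as compound 2 joined differently: 1-methylethenyl in place of prop-1-en-1-yl on a carbonyl carbon. The carbonyl, the chain on the shared core and the number and kind of atoms are unchanged. Among the compounds with values here, no measured pair shows what such a rearrangement does, so the expectation for compound 3 rests on compound 2 alone, with a step from compound 2 to compound 3 of a 1.2-fold higher number from compound 2 to compound 3 (0.07 log units; within the scatter) that stays within the scatter. On that basis compound 3 is expected to give about 9000 nM in this assay, with a likely range from 3500 nM to 25000 nM.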

Compound 3, half-maximal inhibitory concentration in the thyroid hormone receptor beta assay: 23200 nM
For compound 3 the middle estimate is 2.6-fold (0.41 log units) below the measured one; the measured number falls inside the stated range.
By their numbers in the thyroid hormone receptor beta assay, from the lowest: compound 2; then compounds 1 and 3 (each within the scatter of the next).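

In the thyroid hormone receptor beta assay compound 1 gives 17700 nM and compound 2 gives 7600 nM, but these earlier compounds differ in more than one spot and offer no clean comparison at this place. Putting 1-methylethenyl in place of prop-1-en-1-yl on a carbonyl carbon gives in the thyroid hormone receptor beta assay a 3.1-fold higher number from compound 2 to compound 3 (0.48 log units; beyond the scatter), so for this pair the result depends on how the same atoms are joined, not only on which atoms are present. In a physicochemical assay for solubility, in phosphate buffer (a lower number here means a less soluble compound, a higher number a more soluble compound), compound 2 gives 41000 nM and compound 3 gives 37000 nM; the same change gives a 1.1-fold lower number from compound 2 to compound 3 (0.04 log units; within the scatter), and there the two compounds cannot be told apart.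

From the compounds shown here alone, whether an amine or a cyclopropyl group on that carbonyl carbon would bind more strongly or more weakly, and whether the step holds with a longer chain on the shared core, stays open. Nothing available here explains why the two arrangements differ in binding.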